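The source may report more compounds than this note shows. Statements on the series, on what has been measured and on what is new or still open speak of the compounds shown alone.

Compounds measured so far:
compound 1, `CC(C)[C@@H](NC(=O)CCc1ccc(F)cc1)C(=O)N1CCC(c2ccc(Cl)cc2)CC1`, gives 70 nM in an assay on THP-1 cells for displacement of a labelled ligand from C-C chemokine receptor type 1 (Homo sapiens); on this read-out higher numbers stand for weaker inhibition and lower numbers for stronger inhibition.
compound 2, `Cc1ccc(CCC(=O)N[C@@H](C(=O)N2CCC(c3ccc(Cl)cc3)CC2)C(C)C)cc1`, gives 105 nM in this assay.

Compound 2 holds the higher of the two numbers, but its gap to compound 1 is small: a 1.5-fold higher number from compound 1 to compound 2 (0.18 log units; within the scatter). The two values therefore cannot be ordered with confidence.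

Compound 3, `CC(C)[C@@H](NC(=O)c1ccc(F)c(F)c1)C(=O)N1CCC(c2ccc(Cl)cc2)CC1`, has not yet been measured. It differs from compound 2 in one place: 3,4-difluorophenyl in place of 2-(4-methylphenyl)ethyl on a carbonyl carbon. The shared core of compound 2 is kept, while the group on the carbonyl carbon changes from a chain carrying a ring to a ring attached directly, and the methyl on that ring gives way to two fluorines.

Among the compounds with values here, no measured step covers this change. Within the data shown here, the only step in hand, from compound 1 to compound 2, swaps a fluoro for a methyl on the aromatic carbon and stays within the scatter, so it says nothing about removing the two-carbon chain. The expectation for compound 3 must therefore be broad. A somewhat higher number than compound 2 is estimated, a 2.9-fold higher number from compound 2 to compound 3 (0.46 log units; beyond the scatter), since the change is large and the two measured compounds give no guide. Compound 3 is expected to give about 300 nM, between 60 nM and 1500 nM.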

Compound 3, half-maximal inhibitory concentration: 14 nM
Compound 3: the middle estimate sits 21-fold (1.33 log units) above what was measured; measured number outside the range, below it.
By their numbers in this assay, from the lowest: compound 3; then compounds 1 and 2 (each within the scatter of the next).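

At this carbonyl carbon, the group can change substantially and inhibition becomes stronger in this assay: 3,4-difluorophenyl in place of 2-(4-methylphenyl)ethyl gives a 7.5-fold lower number from compound 2 to compound 3 (0.88 log units; beyond the scatter), and the same group in place of 2-(4-fluorophenyl)ethyl gives a 5.0-fold lower number from compound 1 to compound 3 (0.70 log units; beyond the scatter). Within the data shown here, both steps lie beyond the scatter and point the same way, whereas the one earlier step, fluoro to methyl on an aromatic carbon, stayed within it, so this is the first sign that the number responds to the group at this position. Each step, however, removes the ethyl part of the group and alters the fluorines on the ring at the same time, so the gain belongs to the whole replacement and not to either part alone.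

Nothing in hand gives a reason for the lower number. Going by these compounds, it remains open which part of the change carries the gain, and what a plain phenyl, a 2-(3,4-difluorophenyl)ethyl group or a phenyl bearing an amine or a carboxylic acid would give on this carbonyl carbon.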